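Methoxy to ethyl: notes on a small series

The source may hold more compounds than are shown below. What is called first, only, known or untested is meant among the compounds shown, and "the series" means these compounds.

compound 1 `CCc1nc(-c2ccc(OC(F)F)cc2Cl)c(OC)nc1NC(CC)CC` half-life 2 h
compound 2 `CCC(CC)Nc1nc(OC)c(-c2ccc(Cl)cc2Cl)nc1OC` half-life 0.267 h

In an in vitro ADME assay on microsomes (Homo sapiens) for metabolic stability (a higher number here means that the compound lasts longer, a lower number that the compound disappears faster), compound 2 (0.267 h) holds the lower of the two values, the other being that of compound 1 (2 h). The gap between the two lies beyond the scatter. Compound 3 `CCc1nc(-c2ccc(Cl)cc2Cl)c(OC)nc1NC(CC)CC` follows from compound 2 by one change ethyl in place of methoxy on an aromatic carbon with ethyl in place of methoxy on an aromatic carbon, next to the ring nitrogen. Among the compounds with values here, no measured pair isolates this change, so the size of the step in this assay is poorly defined. Within the data shown here, a small rise is expected, not clearly beyond the scatter, and the upper end of the range stays under the sole higher value, that of compound 1 (2 h). The expected step is a 1.9-fold higher number from compound 2 to compound 3 (0.27 log units; within the scatter) and it carries wide uncertainty. The estimate for compound 3 is 0.5 h (range 0.17 h to 1.5 h).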

Compound 3, half-life: 0.7 h
Estimate against measurement, compound 3: 1.4-fold (0.15 log units) below; the range from low to high includes it.
By their numbers in this assay, from the lowest: compound 2; then compound 3; then compound 1.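

In this assay, ethyl in place of methoxy on the aromatic carbon next to the ring nitrogen now has a measured size at this position: a 2.6-fold higher number from compound 2 to compound 3 (0.42 log units; beyond the scatter). With ethyl held constant, chloro in place of difluoromethoxy on an aromatic carbon gives a 2.9-fold lower number from compound 1 to compound 3 (0.46 log units; beyond the scatter), so the other site of difference between the compounds also has a measured step, in the opposite direction. No data at hand explain either step.

The compounds shown leave open whether the ethyl step keeps its size when difluoromethoxy stands in place of chloro, since the methoxy counterpart of compound 1 is absent from this set. They also say nothing about how a longer chain such as propyl, or an amine, would behave at this position in this assay.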